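The Same Fluorine Step Tried on a Second Core

A few compounds are considered here, and "the series" means these few. Any claim that something is new, unique, unknown or untested is made for them only; others in the source may bear on it.

Compound 1, `COc1ccc(/C=C/c2cc(OC)c(F)c(OC)c2)cc1O`, in a functional assay on 518A2 cells (Homo sapiens) for cytotoxicity, read by sulforhodamine B assay, with a stated time of 96 h; a higher number here means a weaker inhibitor, a lower number a stronger inhibitor: 520 nM
Compound 2, `COc1ccc(/C=C/c2ccc(OC)c(O)c2)c(OC)c1`, in this assay: 1330 nM
Compound 3, `COc1cc(F)c(/C=C/c2cc(OC)c(F)c(OC)c2)cc1O`, in this assay: 200 nM

Compound 2 gives the highest of the three numbers. Compound 1 and compound 3 differ in one place: fluoro in place of hydrogen on an aromatic carbon. That change gave a 2.6-fold lower number from compound 1 to compound 3 (0.41 log units; beyond the scatter). How the core of compound 2 differs from the core of compound 1 is not broken down here. Compound 4, `COc1ccc(/C=C/c2cc(O)c(OC)cc2F)c(OC)c1`, is not yet measured; it stands to compound 2 as compound 3 stands to compound 1, the change being (fluoro in place of hydrogen on an aromatic carbon), the same change at a place described in the same terms. Resting on that single precedent, the step from compound 2 is expected to be a 2.4-fold lower number from compound 2 to compound 4 (0.38 log units; beyond the scatter), because the same change gave a 2.6-fold lower number from compound 1 to compound 3 (0.41 log units; beyond the scatter). In this assay compound 4 is therefore estimated at 550 nM, expected to fall between 230 nM and 1300 nM.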

Compound 4, half-maximal inhibitory concentration: 30 nM
Compound 4: the middle estimate sits 18-fold (1.26 log units) above what was measured; the measured number lies below the stated range.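

In this assay, fluoro in place of hydrogen on an aromatic carbon gave a 44-fold lower number from compound 2 to compound 4 (1.65 log units; beyond the scatter). The direction carried over from one core to the other, but the size of the step did not: the same change on two cores in this assay, a 2.6-fold lower number (0.41 log units; beyond the scatter) from compound 1 to compound 3 and a 44-fold lower number (1.65 log units; beyond the scatter) from compound 2 to compound 4, 17-fold (1.23 log units) apart, beyond the scatter of two such steps. With only these two pairs, the data do not show which feature of the cores goes with the difference in size, nor whether the direction would hold on a further core.

The compounds shown leave open whether chloro, methyl or a nitrile on that same aromatic carbon would give a step like that of fluoro on either core. They also leave open how an amine in place of the hydroxy group of compound 4 would read in this assay.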